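The compounds below may be only part of what the source reports. "The series", "measured", "known", "first", "only" and "open" are said of these compounds alone.

Of the compounds shown here, three of one shared core have been measured in a physicochemical assay for solubility, read by HPLC, in phosphate buffer, with a stated time of 24 h, at pH 6.8; on this read-out higher numbers stand for higher solubility and lower numbers for lower solubility. Compound 1 `CC(C)OC(=O)N1CCC2(CC1)CC(CCCOc1ccc(S(C)(=O)=O)c(F)c1)C2` carries a methylsulfonyl group on its aromatic ring; in this assay compound 1 gives only a limit of the assay, < 0.16 ug/mL. Compound 2 `CC(C)c1noc(N2CCC3(CC2)CC(CCCOc2ccc(S(C)(=O)=O)cc2)C3)n1` likewise reaches only a limit in this assay, namely < 0.13 ug/mL. For the measured compounds named here, compound 3 `CC(C)OC(=O)N1CCC2(CC1)CC(CCCOc1ccc(C(=O)N3CCCC3)c(F)c1)C2` is the one compound with a real number: in this assay compound 3 gives 3.85 ug/mL, and the one measured step, an at least 24-fold higher number from compound 1 to compound 3 (1.38 log units; beyond the scatter), is the only guide to how much a change on this aromatic position can move the read-out.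

Compound 4 `CC(C)OC(=O)N1CCC2(CC1)CC(CCCOc1ccc(C(=O)NCC(N)=O)c(F)c1)C2` differs from compound 3 in one place: (carbamoylmethyl)amino in place of pyrrolidin-1-yl on a carbonyl carbon. Going by the values given here, no measured step changes a group on this carbonyl carbon, so the size of the step is uncertain. The change from compound 3 to compound 4 is expected to raise the number, a 3.9-fold higher number from compound 3 to compound 4 (0.59 log units; beyond the scatter), and the estimate for compound 4 in this assay is 15 ug/mL, within a range from 3 ug/mL to 70 ug/mL.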

Compound 4, solubility: 1.77 ug/mL
Compound 4: middle estimate off by 8.5-fold (0.93 log units), on the high side; the measured number lies below the stated range.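

In this assay, the group on this carbonyl carbon matters in its own right: with (carbamoylmethyl)amino in place of pyrrolidin-1-yl, the change gives a 2.2-fold lower number from compound 3 to compound 4 (0.34 log units; beyond the scatter), so an open chain with more hydrogen-bond donors does not give the higher number here. Even so, the earlier large gain over the methylsulfonyl compound is not tied to pyrrolidin-1-yl alone, as the second amide still shows an at least 11-fold higher number from compound 1 to compound 4 (1.04 log units; beyond the scatter). That step has only a floor for its size, since compound 1 gives a limit of the assay and not a number: the limit of < 0.16 ug/mL in this assay, at which 1 of the 4 values shown sits.

For the compounds shown here, only two groups on this carbonyl carbon can be compared, so it remains open how a morpholin-4-yl group, or a longer chain ending in an amine or a carboxylic acid, would read. On these data alone, whether these two groups keep their order on another core, such as that of compound 2, also remains open.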